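Swapping Dimethylamino for Diethylamino in Compound 1

The compounds below may be only part of what the source reports. "The series", "measured", "known", "first", "only" and "open" are said of these compounds alone.

Compound 1 `CN(C)/C=N/c1c(C=O)c(-c2ccccc2)nn1-c1ccccc1` has been measured in a functional assay on NPC-TW01 cells (Homo sapiens) for inhibition, read by MTT assay, with a stated time of 72 h (a lower number here means a stronger inhibitor of growth, a higher number a weaker inhibitor of growth), where compound 1 gives 9300 nM. Two close relatives are known. Compound 2 `CN(C)/C=N/c1c(C=O)c(-c2ccccc2)nn1-c1cccc(Cl)c1` gives 6400 nM, and compound 3 `Cc1ccc(-c2nn(-c3ccccc3)c(/N=C/N(C)C)c2C=O)cc1` gives 9700 nM. Both steps away from compound 1 are small: a 1.5-fold lower number from compound 1 to compound 2 (0.16 log units; within the scatter) and a 1.0-fold higher number from compound 1 to compound 3 (0.02 log units; within the scatter) both stay within the scatter, so compound 1 sits among its neighbours with no difference that this assay can resolve.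

Compound 4 `CCN(/C=N/c1c(C=O)c(-c2ccccc2)nn1-c1ccccc1)CC` differs from compound 1 in one place: diethylamino in place of dimethylamino on a carbon with a double bond to nitrogen. Neither measured step touches this part of the molecule; each exchanges a hydrogen on an aromatic carbon, so neither bears directly on the change to compound 4. What they do show is that small additions elsewhere left this assay almost unmoved. Going by the values given here, with no measured step on the carbon with a double bond to nitrogen, the step of a 1.0-fold lower number from compound 1 to compound 4 (0.01 log units; within the scatter) is estimated to stay within the scatter, with no clear direction. Compound 4 is therefore expected to give 9000 nM, within a range from 4500 nM to 18000 nM.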

Compound 4, concentration for 50% growth inhibition: 30500 nM
Compound 4: the middle estimate sits 3.4-fold (0.53 log units) below what was measured; measured number above the stated range.
By their numbers in this assay, from the lowest: compounds 2, 1 and 3 (each within the scatter of the next); then compound 4.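

Compared with the hydrogen swaps on aromatic carbons, which stayed within the scatter, this change produces a step that can be resolved. In this assay, putting diethylamino in place of dimethylamino gives a 3.3-fold higher number from compound 1 to compound 4 (0.52 log units; beyond the scatter), so compound 4 is a weaker inhibitor of growth than compound 1. This shows that the group on the carbon with a double bond to nitrogen is not a place where any exchange leaves growth inhibition unchanged, although no measurement shown here explains the loss.

Going by these compounds alone, one step gives a direction for only this pair of groups. Still open, as far as these compounds go, is whether a longer chain such as dipropylamino, or a ring amine such as pyrrolidine or morpholine, at this place would raise the number further or bring it back towards that of compound 1.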